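This account rests on a few compounds, and the source may have more. Where it says the series, first, only, none or still open, it means among the compounds named here.

Compound 1 `Cn1ncc([N+](=O)[O-])c1C(=O)Nc1ccc2nc(NC(=O)C3CCCCC3)sc2c1` gives 0.026 ug/mL in a functional assay on WI-38 VA13 cells (Homo sapiens) for cytotoxicity (on this read-out higher numbers stand for an effect only at larger amounts of compound and lower numbers for an effect already at smaller amounts), and compound 2 `CC(C)CC(=O)Nc1nc2ccc(NC(=O)c3c(Cl)cccc3Cl)cc2s1` gives 0.012 ug/mL. Compound 3 `O=C(O)CCC(=O)Nc1nc2ccc(NC(=O)c3c(Cl)cccc3Cl)cc2s1` shares the core of compound 2 and differs from it only in the chain on the carbonyl carbon. In this assay compound 3 gives only a limit, > 6.6 ug/mL, so no number is known for it. The one step measured between a pair of these compounds is an at least 550-fold higher number from compound 2 to compound 3 (2.74 log units; beyond the scatter), and it rests on (the limit of > 6.6 ug/mL in this assay, at which 1 of the 3 values shown sits).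

Compound 4 `COCCOC(=O)Nc1nc2ccc(NC(=O)c3c(Cl)cccc3Cl)cc2s1` differs from compound 3 by 2-methoxyethoxy in place of 2-carboxyethyl on a carbonyl carbon. The measured step bears on this change directly: exchanging isopropyl for carboxymethyl removed the effect entirely, and compound 4 carries no carboxyl group. For the measured compounds named here, the expected step is therefore a fall in the number, an at least 66-fold lower number from compound 3 to compound 4 (1.81 log units; beyond the scatter), back toward the range of compound 2, though a chain with two oxygens on the carbonyl carbon has no measured counterpart here. For compound 4 the estimate in this assay is 0.1 ug/mL, between 0.01 ug/mL and 1 ug/mL.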

Compound 4, half-maximal effective concentration: 0.011 ug/mL
For compound 4 the middle estimate is 9.1-fold (0.96 log units) above the measured one; the range from low to high includes it.
By their numbers in this assay, from the lowest: compounds 4 and 2 (each within the scatter of the next); then compound 1. At a limit, above all of these: compound 3.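

In this assay, 2-carboxyethyl and 2-methoxyethoxy carry the same 5 heavy atoms, 3 carbon and 2 oxygen, on the same carbonyl carbon, yet exchanging one for the other gives an at least 600-fold lower number from compound 3 to compound 4 (2.77 log units; beyond the scatter), so matching atom counts at this position do not give matching read-outs. This step starts from a limit for compound 3, not from a number: the limit of > 6.6 ug/mL in this assay, at which 1 of the 4 values shown sits. Isobutyl and 2-methoxyethoxy on this carbonyl carbon read alike, with a 1.1-fold lower number from compound 2 to compound 4 (0.04 log units; within the scatter), so a chain with oxygen in it can match a chain of carbon alone here.

Whether the carboxylic acid itself accounts for the limit seen with compound 3 remains open. As far as these compounds go, how an amine or a longer chain would read at this position also remains open.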